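This account rests on a few compounds, and the source may have more. Where it says the series, first, only, none or still open, it means among the compounds named here.

In a functional assay on NCI-H460 cells (Homo sapiens) for antiproliferative activity, read by MTT assay, with a stated time of 48 h (on this read-out higher numbers stand for weaker inhibition and lower numbers for stronger inhibition), the measured compounds stand as follows:
- compound 1 `COc1cc(-c2cccc3nc(-c4cccc(Br)c4)oc23)cc(OC)c1OC` gives 3800 nM
- compound 2 `COc1cc(-c2cccc3nc(-c4cccc(N)c4)oc23)cc(OC)c1OC` gives 2600 nM
- compound 3 `COc1cc(-c2cccc3nc(-c4ccc5cc[nH]c5c4)oc23)cc(OC)c1OC` gives 24 nM

Compound 3 has the lowest number of the three, and its gaps to both others lie beyond the scatter. Compound 4 `COc1cc(-c2cccc3nc(-c4cccs4)oc23)cc(OC)c1OC` is not yet measured. It carries thiophen-2-yl in place of 1H-indol-6-yl on an aromatic carbon on an aromatic carbon of the five-membered aromatic ring of the shared core.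

Two large steps bear on this change, a 160-fold lower number from compound 1 to compound 3 (2.20 log units; beyond the scatter) and a 110-fold lower number from compound 2 to compound 3 (2.03 log units; beyond the scatter), and both end at the 1H-indol-6-yl group. Exchanging bromo for amino gave only a 1.5-fold lower number from compound 1 to compound 2 (0.16 log units; within the scatter) and stayed within the scatter. Among the compounds with values here, no thiophen-2-yl compound has been measured, so the comparison is indirect. Compound 4 loses the 1H-indol-6-yl group, so most of that large drop is expected to be reversed. The expected change in this assay is a 63-fold higher number from compound 3 to compound 4 (1.80 log units; beyond the scatter) and is a large rise. The estimate for compound 4 is 1500 nM within an expected range of 300 nM to 6000 nM until it is measured.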

Compound 4, half-maximal inhibitory concentration: 1600 nM
Beside the measured number, compound 4's estimate is 1.1-fold (0.03 log units) below it; the measured number falls inside the stated range.
By their numbers in this assay, from the lowest: compound 3; then compounds 4, 2 and 1 (each within the scatter of the next, the first and the last beyond it).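

In this assay, the step of a 67-fold higher number from compound 3 to compound 4 (1.82 log units; beyond the scatter) shows that a lone five-membered aromatic ring with one hetero atom does not keep the low number of the 1H-indol-6-yl group at this position on the shared core. Thiophen-2-yl cannot be told apart from 3-aminophenyl, with a 1.6-fold lower number from compound 2 to compound 4 (0.21 log units; within the scatter), and it differs only modestly from 3-bromophenyl, with a 2.4-fold lower number from compound 1 to compound 4 (0.38 log units; beyond the scatter), so among these four groups 1H-indol-6-yl alone gives a low number. No measurement given here accounts for this difference.

Thiophen-2-yl lacks both the six-membered carbon ring and the hydrogen-bond donor of 1H-indol-6-yl, and the compounds shown do not separate these two differences. They also leave open how 1H-pyrrol-2-yl, which keeps the ring nitrogen hydrogen without a fused ring, or benzothiophen-6-yl, which keeps two fused rings without it, would stand.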